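Phenyl to Ethynyl on a Nucleoside Core

The source may hold more compounds than are shown below. What is called first, only, known or untested is meant among the compounds shown, and "the series" means these compounds.

Three nucleoside analogues were tested in a functional assay on CEM-DNR-bulk cells (Homo sapiens), read by MTT assay, with a stated time of 72 h; on this read-out higher numbers stand for weaker inhibition and lower numbers for stronger inhibition. Compound 1 `C#Cc1cn([C@@H]2O[C@H](CO)[C@@H](O)[C@H]2O)c2ncnc(NC)c12` carries an ethynyl group on the five-membered ring and a methylamino group on the six-membered ring; in this assay compound 1 gives 18500 nM. Compound 3 `CNc1ncnc2c1c(-c1ccccc1)cn2[C@@H]1O[C@H](CO)[C@@H](O)[C@H]1O` differs from compound 1 only by ethynyl in place of phenyl on an aromatic carbon. In this assay compound 3 reaches only the limit of > 20000 nM, which is a limit of the assay and not a number. Compound 2 `COc1ncnc2c1c(-c1ccccc1)cn2[C@@H]1O[C@H](CO)[C@@H](O)[C@H]1O` differs from compound 3 in the six-membered ring, the difference being (methoxy in place of methylamino on an aromatic carbon). In this assay compound 2 likewise reaches only the limit of > 20000 nM, again a limit and not a number.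

The measured step of an at least 1.0-fold lower number from compound 3 to compound 1 (0.03 log units; that floor lies within the scatter) is therefore only a floor, set by the limit of > 20000 nM in this assay, at which 2 of the 3 values shown sit. The step that the two limits leave unreadable from compound 2 to compound 3 cannot be read for the same reason, since the limit of > 20000 nM in this assay, at which 2 of the 3 values shown sit, stands on both sides.

Compound 4 `C#Cc1cn([C@@H]2O[C@H](CO)[C@@H](O)[C@H]2O)c2ncnc(OC)c12` is not yet measured. Among the measured compounds shown here, it differs from compound 2 by ethynyl in place of phenyl on an aromatic carbon, which is the same change as the one from compound 3 to compound 1, made at the same place. Beside the measured floor an at least 1.0-fold lower number from compound 3 to compound 1 (0.03 log units; that floor lies within the scatter), the expected step is a step that the limit leaves unreadable from compound 2 to compound 4, resting on the fact that compound 1 gives 18500 nM. For compound 4 the expected value in this assay is 22000 nM, estimated to fall between 12000 nM and 60000 nM.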

Compound 4, half-maximal inhibitory concentration: 3490 nM
The estimate for compound 4 lay 6.3-fold (0.80 log units) above the measured number, outside the stated range (below it).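

In this assay, ethynyl in place of phenyl on an aromatic carbon gives an at least 5.7-fold lower number from compound 2 to compound 4 (0.75 log units; beyond the scatter), and with ethynyl already in place, methoxy in place of methylamino gives a 5.3-fold lower number from compound 1 to compound 4 (0.72 log units; beyond the scatter). On the core of compound 2, then, the change from phenyl to ethynyl clearly goes with stronger inhibition, while on the core of compound 3 only a floor within the scatter can be read, so the data do not show whether the change has the same size on both cores: the same change on two cores in this assay, an at least 1.0-fold lower number (0.03 log units; that floor lies within the scatter) from compound 3 to compound 1 and an at least 5.7-fold lower number (0.75 log units; beyond the scatter) from compound 2 to compound 4; the limit leaves it open whether they differ. The true step on each core remains hidden, and neither a matching nor a differing effect can be claimed, as the phenyl compounds give a limit and not a number: the limit of > 20000 nM in this assay, at which 2 of the 4 values shown sit.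

On these data alone, the step between the two phenyl compounds cannot be read, so it stays open whether methoxy in place of methylamino matters when phenyl is present. The compounds shown also leave open what a longer chain on the triple bond would do at that place, or what an unsubstituted amine or a carboxylic acid would do in place of the methoxy group.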